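The source may report more compounds than this note shows. Statements on the series, on what has been measured and on what is new or still open speak of the compounds shown alone.

Measured compounds:
compound 1 `CN1CCN(c2ccc(Nc3ncc4nc(Nc5ccc(F)cc5)n([C@H]5CCCN(C(=O)CO)C5)c4n3)cc2)CC1`, 1.8 nM
compound 2 `CN1CCN(c2ccc(Nc3ncc4nc(Nc5ccc(F)cc5)n(-c5cccc(NC(=O)CO)c5)c4n3)cc2)CC1`, 7.5 nM
compound 3 `CC(=O)Nc1cccc(-n2c(Nc3ccc(F)cc3)nc3cnc(Nc4ccc(N5CCN(C)CC5)cc4)nc32)c1`, 10 nM

All three were tested in a functional assay on HCC827 cells (Homo sapiens) for antiproliferative activity, read by MTT assay, with a stated time of 72 h; a lower number here means a stronger inhibitor, a higher number a weaker inhibitor. Compound 3 gives the highest of the three numbers there; the nearer step is a 1.3-fold higher number from compound 2 to compound 3 (0.12 log units; within the scatter), and the further step is a 5.6-fold higher number from compound 1 to compound 3 (0.74 log units; beyond the scatter). Compound 4 `CCOC(=O)CN1CC[C@H](n2c(Nc3ccc(F)cc3)nc3cnc(Nc4ccc(N5CCN(C)CC5)cc4)nc32)C1` differs from compound 3 in one place: 1-((ethoxycarbonyl)methyl)pyrrolidin-3-yl in place of 3-acetamidophenyl on an aromatic nitrogen.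

Going by the values given here, the step that bears on this change is the one from compound 1 to compound 3, where a saturated ring carrying an acyl group on its nitrogen gave way to the aryl amide and the number rose, a 5.6-fold higher number from compound 1 to compound 3 (0.74 log units; beyond the scatter); the step of a 4.2-fold higher number from compound 1 to compound 2 (0.62 log units; beyond the scatter) points the same way. Among the compounds with values here, compound 4 moves back to a saturated ring on that aromatic nitrogen, though with an ethoxycarbonylmethyl on the ring nitrogen rather than the glycolyl group of compound 1, so no measured pair covers that substituent directly. A modest fall in the number is therefore expected, a 2.5-fold lower number from compound 3 to compound 4 (0.40 log units; beyond the scatter), and compound 4 is estimated at 4 nM with a range of 1.5 nM to 12 nM.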

Compound 4, half-maximal inhibitory concentration: 1810 nM
For compound 4 the middle estimate is 450-fold (2.66 log units) below the measured one, outside the stated range (above it).
By their numbers in this assay, from the lowest: compound 1; then compounds 2 and 3 (each within the scatter of the next); then compound 4.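

In this assay a saturated ring on this aromatic nitrogen does not by itself bring the low number of compound 1: a 1000-fold higher number from compound 1 to compound 4 (3.00 log units; beyond the scatter) separates two saturated rings, 1-((hydroxymethyl)carbonyl)piperidin-3-yl and 1-((ethoxycarbonyl)methyl)pyrrolidin-3-yl. Going by these compounds alone, the new group also falls well short of both aryl amides, with a 180-fold higher number from compound 3 to compound 4 (2.26 log units; beyond the scatter) and a 240-fold higher number from compound 2 to compound 4 (2.38 log units; beyond the scatter), so a change at this position can move the number far more than the earlier steps showed. No measurement given here accounts for this loss.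

Compound 4 differs from compound 1 in both ring size and ring-nitrogen substituent, and the compounds shown do not separate the two. Still open, as far as these compounds go, is how a piperidin-3-yl carrying ethoxycarbonylmethyl, or a pyrrolidin-3-yl carrying a carboxylic acid in place of the ethyl ester, would compare.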